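Carbamate aryl swap on the shared core, compound 4

A few compounds are considered here, and "the series" means these few. Any claim that something is new, unique, unknown or untested is made for them only; others in the source may bear on it.

Measured so far:
compound 1 `CC(C)=CCC1Cc2c(O)cc(=O)n(CCCO)c2CC1(C)C` — 25.6%
compound 2 `CC(C)=CCC1Cc2c(OCc3ccccc3)cc(=O)n(CCCO)c2CC1(C)C` — -0.3%
compound 3 `COc1ccccc1NC(=O)Oc1cc(=O)n(CCCO)c2c1CC(CC=C(C)C)C(C)(C)C2` — 71.1%

In a functional assay on PANC-1 cells (Homo sapiens) for inhibition, read by MTT assay, with a stated time of 24 h, tested at 10 uM (on this read-out higher numbers stand for more inhibition at the one concentration tested (going by the name of the read-out) and lower numbers for less inhibition), compound 3 stands highest of the three, with compound 1 nearest and compound 2 furthest. The two steps onto compound 3 are both large: a number 45.5 percentage points higher from compound 1 to compound 3 (beyond the scatter) and a number 71.4 percentage points higher from compound 2 to compound 3 (beyond the scatter), while a number 25.9 percentage points lower from compound 1 to compound 2 (beyond the scatter) runs the other way.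

Compound 4 `CC(C)=CCC1Cc2c(OC(=O)Nc3ccc(F)cc3F)cc(=O)n(CCCO)c2CC1(C)C` differs from compound 3 in one place: 2,4-difluorophenyl in place of 2-methoxyphenyl on an amide-type nitrogen. Going by the values given here, no measured step bears on this swap directly; the measured steps speak only to putting the carbamoyl group on the aromatic oxygen, which compound 4 keeps. Because of a number 71.4 percentage points higher from compound 2 to compound 3 (beyond the scatter) and a number 45.5 percentage points higher from compound 1 to compound 3 (beyond the scatter) the carbamate itself is taken as the main carrier of the high read-out, so compound 4 is expected to stay well above compound 1 and compound 2, with a step from compound 3 that may fall within the scatter or be a modest decrease. The estimated step is a number 11.1 percentage points lower from compound 3 to compound 4 (beyond the scatter). Compound 4 is expected at 60%, within 35% to 85%.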

Compound 4, a percentage reported as inhibition, at one concentration (the size of the read-out at that concentration, not a potency): 69.7%
Compound 4: middle estimate off by 9.7 percentage points, on the low side, and the stated range covers the measured number.
By their numbers in this assay, from the lowest: compound 2; then compound 1; then compounds 4 and 3 (each within the scatter of the next).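

In this assay the swap on the amide-type nitrogen gives a number 1.4 percentage points lower from compound 3 to compound 4 (within the scatter), so 2-methoxyphenyl and 2,4-difluorophenyl cannot be told apart at this position and the read-out does not rest on the methoxy group. The gain from the carbamate now holds with a second aryl group, with a number 44.1 percentage points higher from compound 1 to compound 4 (beyond the scatter) and a number 70 percentage points higher from compound 2 to compound 4 (beyond the scatter), whereas compound 3 alone could not show that it extended beyond one aryl group. Nothing at hand explains why the two aryl groups read alike.

Open, as far as these compounds go, is whether the amide-type nitrogen needs an aryl group at all, as a cyclohexyl group or a plain butyl chain would show. Also open, from the compounds shown here alone, is how an aryl group carrying an amine or a carboxylic acid would read at this position.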